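The source may hold more compounds than are shown below. What is called first, only, known or untested is meant among the compounds shown, and "the series" means these compounds.

Among the compounds with values here, in a functional assay on HFL1 cells (Homo sapiens) for inhibition, read by sulforhodamine B assay, with a stated time of 48 h (a lower number here means a stronger inhibitor, a higher number a weaker inhibitor), the series so far offers a single number. For compound 1 (`CN(C1=NC(=O)/C(=C/C(Cl)=C/c2ccc([N+](=O)[O-])cc2)S1)c1ccc(O)cc1`) the result reads "not determined" (no result reported). For compound 2 (`O=C1N=C(Nc2nccs2)S/C1=C1\C(=O)Nc2ccc(Br)cc21`) the result also reads "not determined" (no result reported). Compound 3 (`O=C1N=C(Nc2ccc(O)cc2)S/C1=C\c1ccc(Cl)cc1`) gives 20 nM, and with no other number to set against it, its standing within the series cannot be ranked.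

Compound 4 (`O=C1N=C(Nc2ccc(O)cc2)S/C1=C\c1ccccc1`) still awaits measurement. It differs from compound 3 by one change, hydrogen in place of chloro on an aromatic carbon, so that 4-chlorophenyl becomes phenyl. The rest of the structure is shared.

Within the data shown here, no two measured compounds differ in one place, so the series gives no direct guide to the size of this change. The available evidence is limited to the structural change and to compound 3 at 20 nM, which makes any forecast tentative. A small weakening is expected in this assay, only slightly beyond the usual scatter, with the expected move being a 2.5-fold higher number from compound 3 to compound 4 (0.40 log units; beyond the scatter). A result with no real change would not be surprising, and a larger loss remains possible. For compound 4 the estimated value is 50 nM, with an expected range from 10 nM to 300 nM.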

Compound 4, half-maximal inhibitory concentration: 90 nM
Beside the measured number, compound 4's estimate is 1.8-fold (0.26 log units) below it; low and high end bracket the measured number.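

In this assay, within the data shown here, the para position of the benzylidene-free aryl group is not the point to stress; what counts is the aromatic carbon carrying chloro, where hydrogen in place of chloro gives a 4.5-fold higher number from compound 3 to compound 4 (0.65 log units; beyond the scatter) and so provides the first direct reading of this position. Losing that one heavy atom therefore costs a modest but real amount, and the 4-chlorophenyl form holds the stronger value of this pair, while the phenyl form in compound 4 still reads 90 nM in the nanomolar range and so does not depend on chloro for measurable inhibition. Nothing on hand accounts for the size of this step, and the reading stays a single comparison of two substituents on one shared core.

As far as these compounds go, with only chloro and hydrogen compared here, the step fixes neither a trend nor a best group at this position, and it is open whether fluoro, bromo, methoxy, an amine or a carboxylic acid in the same place would match compound 3 or fall short of compound 4. Equally open, from the compounds shown here alone, is whether this step would keep its size on a core with the hydroxyl on the other aromatic ring replaced.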